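This account rests on a few compounds, and the source may have more. Where it says the series, first, only, none or still open, it means among the compounds named here.

Measured so far:
compound 1 `O=C(NCCNc1nccc(-c2c(-c3cccc(F)c3)nc3sccn23)n1)c1c(F)cccc1F`: 11400 nM
compound 2 `O=S(=O)(NCCNc1nccc(-c2c(-c3cccc(F)c3)nc3sccn23)n1)c1ccc(Cl)cc1`: 18600 nM

Both compounds share the same core and differ only in the group carried on the amine nitrogen at the end of the side chain. In a functional assay on SK-MEL-28 cells (Homo sapiens) for cytotoxicity, read by MTT assay (on this read-out higher numbers stand for weaker inhibition and lower numbers for stronger inhibition), compound 1 gives 11400 nM and compound 2 gives 18600 nM. Compound 2 stands at the higher of the two numbers, but the step of a 1.6-fold higher number from compound 1 to compound 2 (0.21 log units; within the scatter) lies within the scatter, so the two compounds cannot be told apart on this read-out.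

Compound 3 `Cc1ccc(S(=O)(=O)NCCNc2nccc(-c3c(-c4cccc(F)c4)nc4sccn34)n2)cc1` keeps the sulfonyl group of compound 2 and changes only its ring substituent: methyl in place of chloro on an aromatic carbon. Among the measured compounds shown here, none of the measured steps bears directly on this change; the only step in hand, from compound 1 to compound 2, swaps the whole group on the nitrogen rather than a substituent on its ring, and it was itself within the scatter. There is therefore no basis for expecting a shift in this assay beyond the scatter in either direction.

Compound 3 is expected to give about 17000 nM, with a range from 7000 nM to 40000 nM. The expected step of a 1.1-fold lower number from compound 2 to compound 3 (0.04 log units; within the scatter) is estimated to stay within the scatter.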

Compound 3, half-maximal inhibitory concentration: > 20000 nM
Compound 3 gave a limit, no number; the forecaster's own chance of this, stated with the estimate: 15%; at least 1.1-fold (0.07 log units) between middle value and limit.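

In this assay compound 3 gives > 20000 nM, which is a limit and not a number. Among the compounds shown here, this is the first view of a change on the ring of the sulfonyl group itself rather than of the whole group on the nitrogen: methyl in place of chloro gives an at least 1.0-fold higher number from compound 2 to compound 3 (0.03 log units; that floor lies within the scatter), so the change shows no shift beyond the scatter, though a floor cannot show how far the true value lies from compound 2. As far as these compounds go, replacing the (2,6-difluorophenyl)carbonyl group with the (4-methylphenyl)sulfonyl group gives an at least 1.7-fold higher number from compound 1 to compound 3 (0.24 log units; that floor lies within the scatter), and the true size of both steps stays unknown because the read-out for compound 3 ends at a limit: the limit of > 20000 nM in this assay, at which 1 of the 3 values shown sits.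

From the compounds shown here alone, it remains open whether any group on this ring can move the number beyond the scatter, for example a methoxy group or an amine in the same place, para to a large group. Going by these compounds, it is also open whether a change elsewhere, such as a longer chain carrying the same sulfonyl group, would separate these compounds more clearly.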